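Nitro for Trifluoromethyl on a Sulfonamide Aryl Ring

The compounds below may be only part of what the source reports. "The series", "measured", "known", "first", "only" and "open" are said of these compounds alone.

Two measured compounds share one core. Compound 1 `CC(C)=CCC1Cc2c(OCCCNS(=O)(=O)c3ccc(C(F)(F)F)cc3)cc(=O)n(CCCO)c2CC1(C)C` in a functional assay on PANC-1 cells (Homo sapiens) for inhibition, read by MTT assay, with a stated time of 24 h, tested at 10 uM (on this read-out lower numbers stand for less inhibition and higher numbers for more inhibition at the one concentration tested (going by the name of the read-out)), gives 0%. Compound 2 `CC(C)=CCC/C(C)=C/CC1Cc2c(OCCCNS(=O)(=O)c3ccc(C(F)(F)F)cc3)cc(=O)n(CCCO)c2CC1(C)C`, which carries 3-methylbut-2-en-1-yl in place of hydrogen on a saturated chain carbon bound to a double-bonded chain carbon, gives in this assay 0%. The step of no change at the digits printed from compound 1 to compound 2 (within the scatter) is no change within the scatter, so compound 2 stands level with compound 1, both at the floor of the read-out.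

Compound 3 `CC(C)=CCC/C(C)=C/CC1Cc2c(OCCCNS(=O)(=O)c3ccc([N+](=O)[O-])cc3)cc(=O)n(CCCO)c2CC1(C)C` differs from compound 2 by nitro in place of trifluoromethyl on an aromatic carbon. Going by the values given here, no measured step touches the sulfonyl aryl ring; the only step in hand concerns the chain on the other end of the molecule, and it showed nothing. Because compound 2 gives in this assay 0%, and because no change at the digits printed from compound 1 to compound 2 (within the scatter) shows that a change elsewhere did not lift the read-out, compound 3 is expected to stay at that same level. The expected step of no change at the digits printed from compound 2 to compound 3 (within the scatter) is none beyond the scatter. Compound 3 is therefore estimated at 0%, with a range from 0% to 12%.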

Compound 3, a percentage reported as inhibition, at one concentration (the size of the read-out at that concentration, not a potency): 0%
Estimate against measurement, compound 3: no gap at the digits printed, within the range that was stated.
By their numbers in this assay, from the lowest: compounds 1, 2 and 3 (each within the scatter of the next).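

In this assay, going by these compounds alone, the swap of 4-(trifluoromethyl)phenyl to 4-nitrophenyl, on an aromatic carbon para to a large group, gives no change at the digits printed from compound 2 to compound 3 (within the scatter), and this is the first reading at the sulfonyl aryl ring. The earlier step, no change at the digits printed from compound 1 to compound 2 (within the scatter), concerned only the chain at the other end of the molecule, so both ends have now been varied once and the read-out has stayed in the same place. Within the data shown here, with compound 3 at 0% in this assay, like the two compounds before it, nitro and trifluoromethyl cannot be told apart here, and this single pair shows only that neither group, on this scaffold and at the one concentration tested, gives a reading that differs from the other. Nothing at hand offers a measured reason for this outcome.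

On these data alone, whether an amine or a carboxylic acid on this aromatic carbon would give a different reading remains open. So does whether a longer chain in the link that carries the sulfonamide would lift the read-out on the shared core.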